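The source may hold more compounds than are shown below. What is called first, only, known or untested is meant among the compounds shown, and "the series" means these compounds.

Measured compounds:
- compound 1, `COc1ccc(S(=O)(=O)n2ccc3cccc(-c4ccc(F)cc4)c32)cc1`: 202 nM
- compound 2, `COc1ccc(S(=O)(=O)N2CCc3cccc(-c4ccc(F)c(F)c4)c32)cc1`: 46 nM
- compound 3, `COc1ccc(S(=O)(=O)N2CCc3cccc(-c4cc(OC)c(OC)c(OC)c4)c32)cc1`: 4670 nM

All three were tested in a functional assay on KB-VIN10 cells (Homo sapiens) for inhibition, with a stated time of 72 h; on this read-out lower numbers stand for stronger inhibition and higher numbers for weaker inhibition. Among them compound 2 gives the lowest number, 46 nM. The nearest is compound 1 with 202 nM, a gap beyond the usual scatter, and compound 3 with 4670 nM lies far higher still.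

Compound 4, `COc1ccc(S(=O)(=O)N2CCc3cccc(-c4cccc(F)c4)c32)cc1`, is not yet measured. Against compound 2 the change is hydrogen in place of fluoro on an aromatic carbon. Going by the values given here, no pair of measured compounds separated by exactly this change exists, so the size of the step is uncertain. Compound 4 is expected to give a somewhat higher number, with the step of a 2.2-fold higher number from compound 2 to compound 4 (0.34 log units; beyond the scatter) possibly still inside the scatter. For compound 4 the estimate is 100 nM, within 35 nM to 300 nM.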

Compound 4, half-maximal inhibitory concentration: 92.4 nM
Estimate against measurement, compound 4: 1.1-fold (0.03 log units) above; the measured number falls inside the stated range.
By their numbers in this assay, from the lowest: compounds 2 and 4 (each within the scatter of the next); then compound 1; then compound 3.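

In this assay, replacing the 3,4-difluorophenyl group with 3-fluorophenyl gives a 2.0-fold higher number from compound 2 to compound 4 (0.30 log units; within the scatter). Going by these compounds alone, this is the first comparison here of compounds that differ in one place, and it shows that hydrogen can stand in for this fluoro, para to a large group, without a step beyond the scatter. Nothing available explains this result.

Open, on these data alone, is what a chloro group or an amine would do on this same carbon. Also open, as far as these compounds go, is whether an unsubstituted phenyl ring, with no fluoro left, would stay within the scatter.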